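A few compounds are considered here, and "the series" means these few. Any claim that something is new, unique, unknown or untested is made for them only; others in the source may bear on it.

Compound 1 `O=C(Nc1ccc(C(F)(F)F)cc1)c1cc(Cl)ccc1O`: in a physicochemical assay for solubility (on this read-out lower numbers stand for lower solubility and higher numbers for higher solubility), compound 1 gives only the assay's limit < 1 ug/mL.
Compound 2 `O=C(Nc1ccc(C(F)(F)F)cc1Cl)c1cc(Cl)ccc1O`: in this assay compound 2 gives only the limit < 1 ug/mL.
Compound 3 `O=C(Nc1ccc(C(F)(F)F)cc1)c1cc(Br)ccc1O`: in this assay compound 3 gives only the limit < 1 ug/mL.

Among the measured compounds shown here, every value here is a limit rather than a number, so no step between the measured compounds can be sized. From compound 1 to compound 2 the change is chloro in place of hydrogen on an aromatic carbon, and the step that the two limits leave unreadable from compound 1 to compound 2. The cores of compound 1 and compound 3 differ by bromo in place of chloro on an aromatic carbon, and that step that the two limits leave unreadable from compound 1 to compound 3.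

Compound 4 `O=C(Nc1ccc(C(F)(F)F)c(Cl)c1)c1cc(Br)ccc1O` carries the same kind of change on the core of compound 3: chloro in place of hydrogen on an aromatic carbon. The place is not the same: in compound 2 the chloro sits ortho to a large group and meta to a trifluoromethyl group, whereas in compound 4 it sits ortho to a trifluoromethyl group and meta to a large group.

For the measured compounds named here, the one thing the measured compounds show is the limit of < 1 ug/mL in this assay, at which 3 of the 3 values shown sit. The step from compound 3 to compound 4 is therefore expected to be a step that the limit leaves unreadable from compound 3 to compound 4, resting on the fact that compound 3 gives < 1 ug/mL and that the unsized steps from compound 1 give no reason to expect a rise. For compound 4 the expected value in this assay is 0.5 ug/mL, most likely again reported only as a limit.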

Compound 4, solubility: < 1 ug/mL
Compound 4 gave a limit, no number; the forecaster's own chance of this, stated with the estimate: 90%; the middle value lies beyond the limit too.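

In this assay no step can be read from compound 3 to compound 4, or between any other pair, because neither compound of a pair gives a number: the limit of < 1 ug/mL in this assay, at which 4 of the 4 values shown sit. The compounds shown leave open how soluble each of them actually is, and so whether swapping in chloro or bromo changes solubility at all.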